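The source may hold more compounds than are shown below. What is called first, only, known or untested is meant among the compounds shown, and "the series" means these compounds.

Measured so far in an ADME assay for permeability, using PAMPA, with a stated time of 30 min, at pH 7.4; a higher number here means that the compound crosses the layer faster, a lower number that the compound crosses the layer more slowly:
- compound 1, `COc1ccc(Cn2c(-c3ccccc3)c(-c3ccccc3)c3c(=N)n(CCO)cnc32)cc1`: > 1000 10^-6 cm/s (a limit of the assay, not a number)
- compound 2, `N=c1c2c(-c3ccccc3)c(-c3ccccc3)n(Cc3ccccc3)c2ncn1C1CCN(Cc2ccccc2)CC1`: "nd" (no result reported)
- compound 3, `N=c1c2c(-c3ccccc3)c(-c3ccccc3)n(CC3CCCCC3)c2ncn1C1CCOCC1`: "nd" (no result reported) (no result reported for compound 3).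

For compound 1 the entry is the limit of > 1000 10^-6 cm/s in this assay, at which 1 of the 3 values shown sits, and gives no number. Compound 2 carries no result in this assay. Compound 3 likewise carries no result, so it stands without a number of its own; of the three entries shown, one is a limit and the other two have no value at all. Going by the values given here, there is no measured pair in this assay that differs in one place, so no step size is known from the series.

Compound 4, `N=c1c2c(-c3ccccc3)c(-c3ccccc3)n(CC3CC3)c2ncn1C1CCOCC1`, differs from compound 3 by cyclopropyl in place of cyclohexyl on a saturated chain carbon bound to an aromatic nitrogen. Among the compounds with values here, with no measured step covering this change, the expectation for the move in this assay is a shift of no more than the usual scatter, in either direction. Compound 4 is expected to give about 800 10^-6 cm/s, in the range from 300 10^-6 cm/s to 1500 10^-6 cm/s, with a fair chance that only a limit is reported.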

Compound 4, apparent permeability: > 1000 10^-6 cm/s
Compound 4 was reported as a limit (the forecaster's own chance of this, stated with the estimate: 40%); middle value at least 1.2-fold (0.09 log units) away from the limit.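

Going by these compounds alone, compound 3 carries no result in this assay and compound 4 gives only a limit, so no step between them can be read. Still open is how cyclopropylmethyl compares with cyclohexylmethyl on the shared core, and how the compounds at the limit differ from one another: the limit of > 1000 10^-6 cm/s in this assay, at which 2 of the 4 values shown sit.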